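The source may report more compounds than this note shows. Statements on the series, on what has been measured and on what is new or still open speak of the compounds shown alone.

Three compounds have been measured in a functional assay on U-937 cells (Homo sapiens) for antiproliferative activity, read by CCK-8 assay, with a stated time of 24 h (a lower number here means a stronger inhibitor, a higher number a weaker inhibitor), so far:

- Compound 1 `CCN(CC)Cc1ccc2nc(NC(=O)NN=C(c3ccccn3)c3ccccn3)sc2c1` gives 9100 nM
- Compound 2 `CN(C)Cc1ccc(NC(=O)N/N=C/c2ccccn2)cc1` gives > 40000 nM as a limit
- Compound 3 `CN(C)Cc1ccc(NC(=O)NN=C(c2ccccn2)c2ccccn2)cc1` gives > 40000 nM as a limit

Compound 3 has no true number here: its reading of > 40000 nM is a limit of the assay. Its place is the limit of > 40000 nM in this assay, at which 2 of the 3 values shown sit, and only compound 1 gives a true number.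

Compound 4 `CC1CCN(Cc2ccc(NC(=O)NN=C(c3ccccn3)c3ccccn3)cc2)CC1` differs from compound 3 in one group. The change is 4-methylpiperidin-1-yl in place of dimethylamino on a saturated chain carbon bound to an aromatic carbon and it puts 4-methylpiperidin-1-yl in place of dimethylamino on a saturated chain carbon bound to an aromatic carbon.

Within the data shown here, no measured pair shows this kind of change, so any expectation rests on thin ground. Compound 1 at 9100 nM shows that a true number can be reached in this assay within this small set, so a modest gain is expected rather than a large one. The expected move is an at least 1.6-fold lower number from compound 3 to compound 4 (0.20 log units; that floor lies within the scatter) towards stronger inhibition, though a second limit would be no surprise. For compound 4 the estimated value is 25000 nM with an expected range of 8000 nM to 60000 nM in this assay.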

Compound 4, half-maximal inhibitory concentration: > 40000 nM
Compound 4 gave a limit, no number (the forecaster's own chance of this, stated with the estimate: 50%); middle value at least 1.6-fold (0.20 log units) from the limit.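

Compound 4 gives > 40000 nM in this assay, a limit and not a number. Among these compounds, compound 3 also sits at a limit, so no step from compound 3 to compound 4 can be read: the limit of > 40000 nM in this assay, at which 3 of the 4 values shown sit. The compounds shown leave open whether 4-methylpiperidin-1-yl in place of dimethylamino changes the reading at all.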